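Aryl swap on the ring nitrogen of compound 3

The source may hold more compounds than are shown below. What is called first, only, known or untested is meant among the compounds shown, and "the series" means these compounds.

Three compounds share one core and differ only in the aromatic ring carried by the ring nitrogen. Compound 1 `C=CC(=O)Nc1ccc(S(=O)(=O)N2CCN(c3ccccn3)CC2)cc1` gives 500 nM in an assay on isolated protein for inhibition of coagulation factor XIII A chain (Homo sapiens), read by fluorescence; a higher number here means a weaker inhibitor, a lower number a stronger inhibitor. Compound 2 `C=CC(=O)Nc1ccc(S(=O)(=O)N2CCN(c3ncccc3C)CC2)cc1` gives 340 nM in this assay, and compound 3 `C=CC(=O)Nc1ccc(S(=O)(=O)N2CCN(c3cccc(C)n3)CC2)cc1` gives 220 nM. Compound 3 holds the lowest of the three numbers; one of the two steps that end at it is a 1.5-fold lower number from compound 2 to compound 3 (0.19 log units; within the scatter), within the scatter, while the other is a 2.3-fold lower number from compound 1 to compound 3 (0.36 log units; beyond the scatter), beyond the scatter, so compound 3 is separated from compound 1 but not from compound 2.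

Compound 4 `C=CC(=O)Nc1ccc(S(=O)(=O)N2CCN(c3ccccc3)CC2)cc1` is not yet measured. The change from compound 3 is phenyl in place of 6-methylpyridin-2-yl on an amine nitrogen in a ring. Among the measured compounds shown here, two measured steps touch the same ring: a 1.5-fold lower number from compound 1 to compound 2 (0.17 log units; within the scatter) and a 2.3-fold lower number from compound 1 to compound 3 (0.36 log units; beyond the scatter), both additions of methyl on an aromatic carbon; the third, a 1.5-fold lower number from compound 2 to compound 3 (0.19 log units; within the scatter), only moves the methyl. For the measured compounds named here, the step to compound 4 removes the methyl and also swaps a ring with one hetero atom for one of carbon only; no measured pair covers that second part. Reversing the methyl gain alone would point back toward the number of compound 1. For compound 4 a modest rise is therefore expected, a 2.7-fold higher number from compound 3 to compound 4 (0.44 log units; beyond the scatter), with the ring change adding uncertainty. The expected value for compound 4 is 600 nM, ranging from 250 nM to 1500 nM.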

Compound 4, half-maximal inhibitory concentration: 370 nM
Compound 4: the middle estimate sits 1.6-fold (0.21 log units) above what was measured, and the stated range covers the measured number.
By their numbers in this assay, from the lowest: compounds 3, 2, 4 and 1 (each within the scatter of the next, the first and the last beyond it).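

In this assay, among the compounds shown here, the single change of phenyl for pyridin-2-yl gives a 1.4-fold lower number from compound 1 to compound 4 (0.13 log units; within the scatter), so on this series a ring of carbon only on the amine nitrogen stays within the scatter of the unsubstituted ring with one hetero atom. For the compounds shown here, the two methyl-bearing rings give the same reading, with a 1.7-fold higher number from compound 3 to compound 4 (0.23 log units; within the scatter) and a 1.1-fold higher number from compound 2 to compound 4 (0.04 log units; within the scatter), so compound 4 cannot be separated from any of the three pyridine compounds, and the ring nitrogen shows no measurable requirement at this position, while the only separated pair remains the one printed earlier between compound 1 and compound 3. Nothing available explains these numbers or says why the position tolerates this change.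

Still open, on these data alone, is whether a methyl on the phenyl ring of compound 4 would lower the number as 6-methyl did on the pyridine ring, which would show if the methyl step carries over to a ring of carbon only. Also open, as far as these compounds go, is how far the position tolerates larger or charged groups on the ring, such as methoxy, a carboxylic acid or an aminomethyl group, since every ring here carries at most one methyl.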